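Capping the carboxy group of compound 1

The source may report more compounds than this note shows. Statements on the series, on what has been measured and on what is new or still open speak of the compounds shown alone.

Values in a physicochemical assay for lipophilicity, at pH 7.4 (on this read-out higher numbers stand for higher lipophilicity and lower numbers for lower lipophilicity), are as follows
compound 1 `CCc1ccc(N(CC(C)C)S(=O)(=O)c2ccc3cc(OCC4CCOCC4)c(C(=O)O)cc3c2)cc1` gives 1.77
compound 2 `CCc1ccc(N(CC(C)C)S(=O)(=O)c2ccc3c(c2)C(=O)C[C@@H](C2CCOCC2)O3)cc1` gives 4.2
compound 3 `CCc1ccc(N(CC(C)C)S(=O)(=O)c2ccc3c(c2)C(=O)C[C@H](C2CCOCC2)O3)cc1` gives 4.24

Compound 1 stands lowest of the three. Compound 4 `CCc1ccc(N(CC(C)C)S(=O)(=O)c2ccc3cc(OCC4CCOCC4)c(C(=O)OCC4CCOCC4)cc3c2)cc1` differs from it by (oxan-4-yl)methyl in place of hydrogen on an oxygen next to a carbonyl group and so carboxy becomes ((oxan-4-yl)methoxy)carbonyl. Among the compounds with values here, the one measured step, a number 0.04 log units higher from compound 2 to compound 3 (within the scatter), reflects the fact that compounds 2 and 3 differ only in the configuration as drawn and does not bear on this change. Within the data shown here, the only guide is that compound 2, with no carboxy group, gives 4.2 and compound 3, also without one, gives 4.24 in the same read-out. A large rise beyond the scatter is therefore expected, estimated as a number 2.83 log units higher from compound 1 to compound 4 (beyond the scatter) in this assay overall. Compound 4 is expected near 4.6 (estimated range 3.9 to 5.3).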

Compound 4, distribution coefficient: 6.34
Compound 4: the middle estimate sits 1.74 log units below what was measured, outside the stated range (above it).
By their numbers in this assay, from the lowest: compound 1; then compounds 2 and 3 (each within the scatter of the next); then compound 4.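

In this assay the carboxy position of compound 1 proves strongly responsive: ((oxan-4-yl)methoxy)carbonyl in place of carboxy gives a number 4.57 log units higher from compound 1 to compound 4 (beyond the scatter) and is the only change at this position among the compounds shown. Replacing hydrogen with (oxan-4-yl)methyl on this oxygen therefore moves the read-out far beyond the scatter. Nothing available accounts for the size of this step.

Going by these compounds, what stays open is whether a simple methyl ester or a primary amide at this place would move the read-out as far. Such a compound would help separate the loss of the hydrogen from the contribution of the ring that enters.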